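The source may report more compounds than this note shows. Statements on the series, on what has been measured and on what is new or still open speak of the compounds shown alone.

For the measured compounds named here, compound 3 `O=C(CN(c1nc(Cl)nc2[nH]cnc12)C1CC1)N[C@@H](CO)C(=O)O` gives 43.9% in a functional assay on the whole organism (Tail, strain ICR) with Mus musculus as the target, in the tail flick test, with a stated time of 90 min, at a dose of 25 umol/kg by the oral route (on this read-out higher numbers stand for a stronger effect at the one dose given and lower numbers for a weaker effect), the highest of the three numbers so far, though compound 2 `NC(=O)CC[C@H](NC(=O)CN(c1nc(Cl)nc2[nH]cnc12)C1CC1)C(=O)O` gives 41.1% and the step of a number 2.8 percentage points higher from compound 2 to compound 3 (within the scatter) lies within the scatter; only compound 1 `O=C(O)C[C@H](NC(=O)CN(c1nc(Cl)nc2[nH]cnc12)C1CC1)C(=O)O` with 25.1% stands apart, the step of a number 18.8 percentage points higher from compound 1 to compound 3 (beyond the scatter) being beyond it. Compound 4 `NCCCC[C@H](NC(=O)CN(c1nc(Cl)nc2[nH]cnc12)C1CC1)C(=O)O` differs from compound 3 by 3-aminopropyl in place of hydroxy on a saturated chain carbon, two bonds along the chain from an amide-type nitrogen and a carbonyl carbon. The steps of a number 18.8 percentage points higher from compound 1 to compound 3 (beyond the scatter) and a number 2.8 percentage points higher from compound 2 to compound 3 (within the scatter) show that exchanging the group at this place can move the read-out modestly or not at all, and nothing measured yet contains 3-aminopropyl. Compound 4 is therefore expected to land near compound 3, with a step of a number 3.9 percentage points lower from compound 3 to compound 4 (within the scatter), and an estimated activity of 40% within a range from 20% to 60%.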

Compound 4, a percentage reported as activity, at one dose (the size of the read-out at that dose, not a potency): 28.8%
For compound 4 the middle estimate is 11.2 percentage points above the measured one; the measured number falls inside the stated range.
By their numbers in this assay, from the lowest: compounds 1 and 4 (each within the scatter of the next); then compounds 2 and 3 (each within the scatter of the next).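

In this assay, this position does not tolerate every change: 3-aminopropyl in place of hydroxy gives a number 15.1 percentage points lower from compound 3 to compound 4 (beyond the scatter), and 2-aminoethyl in place of carbamoyl gives a number 12.3 percentage points lower from compound 2 to compound 4 (beyond the scatter). Against the carboxy of compound 1 there is only a number 3.7 percentage points higher from compound 1 to compound 4 (within the scatter), so two different groups now share the lower level, where earlier only compound 1 stood there. On these data alone, whether the amine or the chain carries this drop stays open, as a plain butyl chain or a shorter amine such as aminomethyl would be needed to separate them. No evidence here accounts for the drop.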